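The source may report more compounds than this note shows. Statements on the series, on what has been measured and on what is new or still open speak of the compounds shown alone.

Compound 1, `CC1=C(C(=O)Nc2ccc(F)cc2)C(c2ccc([N+](=O)[O-])cc2)N=C(SCc2ccccc2Cl)N1`, gives 21.6%.
Compound 2, `CC1=C(C(=O)Nc2ccc(Br)cc2)C(c2ccc(Cl)cc2Cl)N=C(SCc2ccccc2Cl)N1`, gives 38.1%.
Compound 3, `COc1ccc(C2N=C(SCc3ccccc3Cl)NC(C)=C2C(=O)Nc2ccc(Br)cc2)cc1`, gives 20.6%.

All three were tested in a functional assay on the whole organism (artery, strain albino) with Rattus norvegicus as the target, with a stated time of 360 min, at a dose of 10 mg/kg by the oral route; a lower number here means less inhibition, a higher number more inhibition at the dose given (going by the name of the read-out). Compound 3 has the lowest of the three numbers, but compound 1 lies within the scatter of it, so the two cannot be ordered. Among the measured compounds shown here, compound 2 stands apart: the one step beyond the scatter is a number 17.5 percentage points lower from compound 2 to compound 3 (beyond the scatter), which came with 4-methoxyphenyl in place of 2,4-dichlorophenyl on a saturated ring carbon.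

Compound 4, `COc1ccc(C2N=C(SCc3ccc(Cl)cc3)NC(C)=C2C(=O)Nc2ccc(Br)cc2)cc1`, has not yet been measured. It differs from compound 3 by 4-chlorophenyl in place of 2-chlorophenyl on a saturated chain carbon bound to a sulfur. For the measured compounds named here, no measured step touches this part of the shared core; the only step known concerns a different place, so there is no basis for expecting a change beyond the scatter. Compound 4 is therefore expected to give about 22%, within a range of 10% to 36%. The step this estimate means, a number 1.4 percentage points higher from compound 3 to compound 4 (within the scatter), is expected to stay within the scatter.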

Compound 4, a percentage reported as inhibition, in the whole organism at one dose (the size of the read-out at that dose, not a potency): 39.2%
Compound 4: the middle estimate sits 17.2 percentage points below what was measured, and the stated range ends below it.
By their numbers in this assay, from the lowest: compounds 3 and 1 (each within the scatter of the next); then compounds 2 and 4 (each within the scatter of the next).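

In this assay, the same atoms joined differently give a different result: the change from 2-chlorobenzyl to 4-chlorobenzyl on the sulfur comes with a number 18.6 percentage points higher from compound 3 to compound 4 (beyond the scatter), so where the chlorine sits on this ring matters at the dose given. This is the first step shown at this part of the molecule, and it means that the number responds here as well as at the saturated ring carbon. Nothing available explains why the chlorine's place has this effect.

This change is seen in one pair only, with 4-methoxyphenyl on the ring carbon and 4-bromophenyl on the amide, so whether it holds alongside other groups is open. As far as these compounds go, how a plain benzyl group, a 4-methoxybenzyl group or a longer chain such as phenylethyl on the sulfur would read also remains open.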